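The compounds below may be only part of what the source reports. "The series", "measured", "known", "first", "only" and "open" are said of these compounds alone.

Working notes on the shared core. Compound 1 `Cc1cc(S(=O)(=O)N2CCCC(Cn3ccnc3)C2)ccc1F` gives 24 nM in an assay on isolated protein for inhibition of Aromatase (Homo sapiens), read by fluorescence; a lower number here means a stronger inhibitor, a higher number a weaker inhibitor. Compound 2 `O=[N+]([O-])c1cccc(Cl)c1Oc1cccc(S(=O)(=O)N2CCCC(Cn3ccnc3)C2)c1` gives 9 nM in this assay, and compound 3 `O=S(=O)(c1cccc2nsnc12)N1CCCC(Cn2ccnc2)C1` gives 54 nM. Among the three numbers, compound 1 stands second highest: its nearest neighbour is compound 3, whose number is higher by a margin beyond the scatter, and the furthest is compound 2, whose number is lower, again beyond the scatter. No pair among these three differs in one place only, so no single step between measured compounds is available to anchor the change now under consideration.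

Compound 4 `O=S(=O)(c1ccc(F)cc1)N1CCCC(Cn2ccnc2)C1` is the next compound, not yet measured in this assay. It differs from compound 1 by hydrogen in place of methyl on an aromatic carbon. The other two measured compounds carry different aryl groups altogether and give no direct read on a lone methyl. With nothing to anchor it, the expectation is a small step, if any, toward a higher number, most likely within or only marginally beyond the scatter. Compound 4 is expected to give 40 nM in this assay, with a range from 15 nM to 110 nM. The estimated step from compound 1 to compound 4 is a 1.7-fold higher number from compound 1 to compound 4 (0.22 log units; within the scatter).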

Compound 4, half-maximal inhibitory concentration: 51 nM
Estimate against measurement, compound 4: 1.3-fold (0.11 log units) below, and the stated range covers the measured number.
By their numbers in this assay, from the lowest: compound 2; then compound 1; then compounds 4 and 3 (each within the scatter of the next).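

Within the shared core, this is the first change in one place that can be read: in this assay, hydrogen in place of methyl on an aromatic carbon, ortho to a fluoro group and meta to a large group, gives a 2.1-fold higher number from compound 1 to compound 4 (0.33 log units; beyond the scatter). A single carbon at this position is therefore enough to move the number beyond the scatter, although the step remains modest. This is one step at one position, and no measurement offered here explains why the number moves.

Going by these compounds, whether the methyl itself matters at this position, or whether other groups there would give a similar or larger step, remains open: a chloro group, a methoxy group, an ethyl chain, an amine or a carboxylic acid in the same place would begin to separate these possibilities. Also open is whether the same change would carry a similar step on other aryl groups, including those of compound 2 and compound 3, since neither forms a one-place pair with another compound shown.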